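Fluoro for methoxy on a second core in HepG2

The compounds below may be only part of what the source reports. "The series", "measured", "known", "first", "only" and "open" are said of these compounds alone.

Measured so far:
compound 1 `COc1ccc(/C=C/C(=O)C(=Cc2ccc(O)c(OC)c2)C(=O)/C=C/c2ccc(OC)cc2OC)c(OC)c1`: 510 nM
compound 2 `COc1ccc(/C=C/C(=O)C(=Cc2ccc(O)c(F)c2)C(=O)/C=C/c2ccc(OC)cc2OC)c(OC)c1`: 1760 nM
compound 3 `COc1cc(OC)c(/C=C/C(=O)C(=Cc2ccc(O)c(OC)c2)C(=O)/C=C/c2c(OC)cc(OC)cc2OC)c(OC)c1`: 670 nM

Of the compounds shown here, three have been tested in a functional assay on HepG2 cells (Homo sapiens) for antiproliferative activity, read by sulforhodamine B assay, with a stated time of 48 h; a lower number here means a stronger inhibitor, a higher number a weaker inhibitor. Compound 1 gives 510 nM in this assay, and compound 2, which differs from it only by fluoro in place of methoxy on an aromatic carbon, gives 1760 nM. That single exchange produced a 3.5-fold higher number from compound 1 to compound 2 (0.54 log units; beyond the scatter). Compound 3 carries a different core; how its core differs from that of compound 1 is not broken down here. In this assay compound 3 gives 670 nM, which places it close to compound 1 and apart from compound 2.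

Compound 4 `COc1cc(OC)c(/C=C/C(=O)C(=Cc2ccc(O)c(F)c2)C(=O)/C=C/c2c(OC)cc(OC)cc2OC)c(OC)c1` has not yet been measured. It stands to compound 3 as compound 2 stands to compound 1: the change is fluoro in place of methoxy on an aromatic carbon, and its place description matches that of the earlier pair word for word, so it is the same change made on a second core. Among the compounds shown this exchange occurs twice in all, once measured and once not.

The expectation for compound 4 rests on the step from compound 1 to compound 2, a 3.5-fold higher number from compound 1 to compound 2 (0.54 log units; beyond the scatter), applied to the value of compound 3, 670 nM. Because a 3.5-fold higher number from compound 1 to compound 2 (0.54 log units; beyond the scatter) lay beyond the scatter, a step of similar size is expected here as well, a 3.3-fold higher number from compound 3 to compound 4 (0.52 log units; beyond the scatter). For the measured compounds named here, compound 4 is therefore estimated at 2200 nM in this assay, with a plausible range from 1000 nM to 4800 nM, the uncertainty reflecting that only one earlier example of this change is available.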

Compound 4, half-maximal inhibitory concentration: 810 nM
For compound 4 the middle estimate is 2.7-fold (0.43 log units) above the measured one; the whole stated range lies above it.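

In this assay, replacing 4-hydroxy-3-methoxyphenyl with 3-fluoro-4-hydroxyphenyl on the core of compound 3 gives a 1.2-fold higher number from compound 3 to compound 4 (0.08 log units; within the scatter), so on this core the exchange leaves no readable mark on the antiproliferative read-out, although it weakened the number on the core of compound 1. The size of the step therefore did not carry from one core to the other in this series, and the earlier step alone would have been a poor guide to the later one: the same change on two cores in this assay, a 3.5-fold higher number (0.54 log units; beyond the scatter) from compound 1 to compound 2 and a 1.2-fold higher number (0.08 log units; within the scatter) from compound 3 to compound 4, 2.9-fold (0.46 log units) apart, beyond the scatter of two such steps. For the compounds shown here, with only one pair on each core, this shows that the core can alter the outcome of the exchange, but it does not show which of the differences between the two cores is responsible, nor how the same exchange would read on a third core.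

The compounds shown leave open how a chloro, a methyl, an ethoxy or an amino group in the same place would read on either core, and so whether the contrast belongs to fluoro alone or extends to other replacements for methoxy. They also leave open whether the contrast between the two cores would hold in cell lines other than HepG2 or at exposure times other than the one used here.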